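A few compounds are considered here, and "the series" means these few. Any claim that something is new, unique, unknown or untested is made for them only; others in the source may bear on it.

Values in a physicochemical assay for lipophilicity, using the shake flask method, measured as octanol-water partition, at pH 7.4; on this read-out higher numbers stand for higher lipophilicity and lower numbers for lower lipophilicity:
- compound 1 `CC(=O)N[C@@H]1CCC[C@H](C(=O)Nc2cc(-c3cnc4ccccn34)c(Cl)cn2)C1`: 3
- compound 2 `CC(=O)N[C@@H]1CCC[C@H](C(=O)Nc2cc(-c3nnn4ccccc34)c(Cl)cn2)C1`: 2

Within the data shown here, compound 2, at 2, holds the lower of the two numbers so far. Compound 3 `CC(=O)N[C@@H]1CCC[C@H](C(=O)Nc2cc(-c3cnn4c3COCC4)c(Cl)cn2)C1` has not been measured yet. It differs from compound 2 in a group of 9 heavy atoms (6 carbon, 2 nitrogen, 1 oxygen; one five-membered aromatic ring with 2 hetero atoms, one six-membered non-aromatic ring with 2 hetero atoms) in place of a group of 9 heavy atoms (6 carbon, 3 nitrogen; one five-membered aromatic ring with 3 hetero atoms, one six-membered aromatic ring with 1 hetero atom), on an aromatic carbon. The change lies on an aromatic carbon of a six-membered aromatic ring, ortho to a chloro group.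

Among the measured compounds shown here, one measured step bears on this change: a number 1.00 log units lower from compound 1 to compound 2 (beyond the scatter), a modest step at the same place. That step exchanged one group with two aromatic rings for another, whereas the entering group here has a six-membered non-aromatic ring with 2 hetero atoms. For the measured compounds named here, no measured step covers such a ring, so the guide is loose. In this assay, a smaller step than that one is expected, slightly downward and probably within the scatter, with the expected change being a number 0.20 log units lower from compound 2 to compound 3 (within the scatter). For compound 3 the estimated value is 1.8, with an expected range of 1.3 to 2.3.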

Compound 3, distribution coefficient: 2.4
Beside the measured number, compound 3's estimate is 0.60 log units below it; measured number above the stated range.
By their numbers in this assay, from the lowest: compound 2; then compound 3; then compound 1.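

In this assay, three groups with the same heavy-atom count on the aromatic carbon ortho to a chloro group now give numbers that separate beyond the scatter: a number 0.40 log units higher from compound 2 to compound 3 (beyond the scatter), and a number 0.60 log units lower from compound 1 to compound 3 (beyond the scatter). The group with a six-membered non-aromatic ring with 2 hetero atoms therefore reads above the group of compound 2 and below the group of compound 1, so a six-membered non-aromatic ring in place of an aromatic one does not put the read-out at either end of this short series. Nothing available accounts for this order.

Going by these compounds, it remains open how a group carrying an amine or a carboxylic acid on the six-membered non-aromatic ring would read at this place. On these data alone, it is also open whether these steps would keep their size and direction on a different core.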